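A Methyl Added to Compound 2: Expected Cytotoxicity

The source may report more compounds than this note shows. Statements on the series, on what has been measured and on what is new or still open speak of the compounds shown alone.

Compound 1 `Nc1cc(-c2ccccc2)ccc1Cn1cncc1CNc1ccc(-c2cncs2)c(-c2ccccc2)c1`: > 1000 nM
Compound 2 `Cc1ccccc1-c1cc(NCc2cncn2Cc2ccc(-c3ccccc3)cc2)ccc1-c1nc2ccccc2s1`: > 1000 nM

In a toxicity assay on NIH3T3 cells (Mus musculus) for cytotoxicity, read by resazurin assay (a lower number here means that less compound is needed, a higher number that more compound is needed for the effect), compound 2 gives only a limit, > 1000 nM. Compound 1 likewise gives only a limit in this assay, > 1000 nM. Both values rest on (the limit of > 1000 nM in this assay, at which 2 of the 2 values shown sit), so neither compound shows a measurable number. Compound 3 `Cc1cccc(-c2cc(NCc3cncn3Cc3ccc(-c4ccccc4)cc3)ccc2-c2nc3ccccc3s2)c1C` has not yet been measured; it differs from compound 2 by methyl in place of hydrogen on an aromatic carbon. Among the compounds with values here, since both known values are limits, no measured step can be sized, and the expected step that the limit leaves unreadable from compound 2 to compound 3 is none beyond the scatter. Compound 3 is therefore expected to give about 1500 nM, somewhere between 700 nM and 4000 nM, most likely again only a limit.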

Compound 3, half-maximal effective concentration: > 1000 nM
Compound 3 was reported as a limit (the forecaster's own chance of this, stated with the estimate: 80%); the middle value is on the limit's open side.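

Within the data shown here, compound 2 and compound 3 both stop at a limit in this assay and no step between them can be read: the limit of > 1000 nM in this assay, at which 3 of the 3 values shown sit. As far as these compounds go, how much of either compound produces the effect, and whether the added methyl changes that amount, stays open.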